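Compound 3 Trades Furan-2-yl for Ethynyl

A few compounds are considered here, and "the series" means these few. Any claim that something is new, unique, unknown or untested is made for them only; others in the source may bear on it.

In a functional assay on A549 cells (Homo sapiens), read by MTT assay, with a stated time of 72 h (on this read-out higher numbers stand for weaker inhibition and lower numbers for stronger inhibition), compound 1 (`Nc1nc(N)c2c(-c3ccco3)cn([C@@H]3O[C@H](CO)[C@@H](O)[C@H]3O)c2n1`) gives only a limit, > 20000 nM. Compound 2 (`Nc1nc(N)c2c(-c3ccsc3)cn([C@@H]3O[C@H](CO)[C@@H](O)[C@H]3O)c2n1`) also gives only a limit, > 100000 nM. Compound 3 (`COc1nc(N)nc2c1c(-c1ccco1)cn2[C@@H]1O[C@H](CO)[C@@H](O)[C@H]1O`) again gives only a limit, > 20000 nM, which is the limit of > 20000 nM in this assay, at which 2 of the 3 values shown sit.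

Compound 4 (`C#Cc1cn([C@@H]2O[C@H](CO)[C@@H](O)[C@H]2O)c2nc(N)nc(OC)c12`) has ethynyl in place of furan-2-yl on an aromatic carbon. Among the measured compounds shown here, two measured steps bear on this change: a step that the two limits leave unreadable from compound 1 to compound 2 alters the same substituent, and a step that the two limits leave unreadable from compound 1 to compound 3 leads to the methoxy compound. Neither has a readable size, so they give no measure for the new change. No step beyond the scatter is therefore expected in this assay, and the estimated change is a number no higher from compound 3 to compound 4 (the limit leaves the size open). The estimate for compound 4 is 20000 nM, with an expected range from 4000 nM to 100000 nM.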

Compound 4, half-maximal inhibitory concentration: > 100000 nM
Compound 4 gave a limit, no number; the forecaster's own chance of this, stated with the estimate: 70%; middle value at least 5.0-fold (0.69 log units) from the limit.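

Compound 3 and compound 4 each give only a limit in this assay, so the step between them cannot be read. The compounds shown leave open how far furan-2-yl and ethynyl differ at this aromatic carbon.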